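Swapping an Aryloxy Group for Benzyl in a Prostacyclin Synthase Series

A few compounds are considered here, and "the series" means these few. Any claim that something is new, unique, unknown or untested is made for them only; others in the source may bear on it.

Of the compounds shown here, three sharing one core have been measured in an assay for inhibition of prostacyclin synthase (Homo sapiens), using microsomes; on this read-out higher numbers stand for weaker inhibition and lower numbers for stronger inhibition. Compound 2 `CC(C)(Oc1ccc(F)cc1)C1OCC(C/C=C\CCC(=O)O)C(c2cccnc2)O1` gives 2000 nM, the lowest number of the three and so the strongest inhibitor among them. Compound 1 `CSc1ccc(OC(C)(C)C2OCC(C/C=C\CCC(=O)O)C(c3cccnc3)O2)c([N+](=O)[O-])c1` gives 5000 nM, and the step of a 2.5-fold lower number from compound 1 to compound 2 (0.40 log units; beyond the scatter) separates these two. Compound 3 `COc1ccc(OC(C)(C)C2OCC(C/C=C\CCC(=O)O)C(c3cccnc3)O2)c([N+](=O)[O-])c1` gives 23000 nM; the step of a 12-fold higher number from compound 2 to compound 3 (1.06 log units; beyond the scatter) puts it furthest from compound 2, while a 4.6-fold higher number from compound 1 to compound 3 (0.66 log units; beyond the scatter) ties it to compound 1.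

Compound 4 `CC(C)(Cc1ccccc1)C1OCC(C/C=C\CCC(=O)O)C(c2cccnc2)O1` has not yet been measured. Its difference from compound 2 is benzyl in place of 4-fluorophenoxy on a saturated chain carbon bound to two saturated chain carbons and a saturated ring carbon. Of the measured steps, only a 2.5-fold lower number from compound 1 to compound 2 (0.40 log units; beyond the scatter) concerns the group on that saturated chain carbon, and it was modest, yet there the linking oxygen was kept. Among the measured compounds shown here, no measured step exchanges that oxygen for a carbon, as happens here. A modest step in this assay in either direction therefore seems likely, with no firm lean. Compound 4 is estimated at 3000 nM, in a range from 800 nM to 12000 nM. This corresponds to an expected step of a 1.5-fold higher number from compound 2 to compound 4 (0.18 log units; within the scatter).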

Compound 4, half-maximal inhibitory concentration: 13000 nM
The estimate for compound 4 lay 4.3-fold (0.64 log units) below the measured number; the whole stated range lies below it.
By their numbers in this assay, from the lowest: compound 2; then compound 1; then compounds 4 and 3 (each within the scatter of the next).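

The linking oxygen itself turns out to matter at this position: in this assay the exchange gives a 6.5-fold higher number from compound 2 to compound 4 (0.81 log units; beyond the scatter) and so weakens inhibition. The earlier compounds shown here changed only the substituents on the aryl ring while keeping that oxygen, so they could not show that a change in the link, here with the ring kept, also moves the number beyond the scatter. This single exchange removes the oxygen and the fluorine together, so the step cannot be assigned to either one, and nothing available here explains it.

As far as these compounds go, what a phenoxy group or a 4-fluorobenzyl group would give on this carbon stays open, and those two would separate the oxygen from the fluorine. Also open, from the compounds shown here alone, is how a sulfur atom or an amine as the link would compare.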